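Benzyloxy in place of bromo: notes towards compound 4

The source may report more compounds than this note shows. Statements on the series, on what has been measured and on what is new or still open speak of the compounds shown alone.

In a functional assay on MCF7 cells (Homo sapiens) for antiproliferative activity, read by MTT assay, with a stated time of 48 h (a lower number here means a stronger inhibitor, a higher number a weaker inhibitor), compound 1 (`CC(=O)N1N=C(c2ccc3ccccc3c2)OC1c1ccc(Br)cc1`) gives 5.07 ug/mL, compound 2 (`CC(=O)N1N=C(c2ccc3ccccc3c2)OC1c1cccnc1`) gives 2.61 ug/mL and compound 3 (`CC(=O)N1N=C(c2ccc3ccccc3c2)OC1c1ccsc1`) gives 7.98 ug/mL. The reference value stands within the scatter of the other two: a 1.9-fold lower number from compound 1 to compound 2 (0.29 log units; within the scatter) and a 1.6-fold higher number from compound 1 to compound 3 (0.20 log units; within the scatter). Only a 3.1-fold higher number from compound 2 to compound 3 (0.49 log units; beyond the scatter) lies beyond the scatter, and modestly.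

Compound 4 (`CC(=O)N1N=C(c2ccc3ccccc3c2)OC1c1ccc(OCc2ccccc2)cc1`) carries benzyloxy in place of bromo on an aromatic carbon. The measured steps replace the whole 4-bromophenyl group, so they bear only indirectly, and no measurement tests this substituent. No step beyond the scatter is expected in this assay, and no direction is favoured: the estimate is a 1.0-fold lower number from compound 1 to compound 4 (0.01 log units; within the scatter). For compound 4 the expected value is 5 ug/mL, with an estimated range of 2 ug/mL to 12.5 ug/mL.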

Compound 4, half-maximal inhibitory concentration: 5.49 ug/mL
Beside the measured number, compound 4's estimate is 1.1-fold (0.04 log units) below it, within the range that was stated.
By their numbers in this assay, from the lowest: compounds 2, 1, 4 and 3 (each within the scatter of the next, the first and the last beyond it).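

Unlike the steps that replace the whole 4-bromophenyl group, this change keeps that ring and alters only the group on its aromatic carbon, para to a large group: in this assay it gives a 1.1-fold higher number from compound 1 to compound 4 (0.03 log units; within the scatter) for the exchange. Bromo, with 1 heavy atom, gives way to benzyloxy, with 8 heavy atoms and an added aromatic ring, without a step beyond the scatter, so at this position the added bulk of this one group carries no measurable penalty. No measurement on hand accounts for this result.

Going by these compounds, how an amine or a carboxylic acid would read at this position remains open. Also open, on these data alone, is whether methoxy would match benzyloxy.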